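Swapping a Cyclohexylphenyl Group for a Difluorophenyl Group

The compounds below may be only part of what the source reports. "The series", "measured", "known", "first", "only" and "open" are said of these compounds alone.

Compound 1 `CC#CC(CC(=O)O)c1ccc(OCc2ccn3cc(-c4ccc(C5CCCCC5)cc4)nc3c2)cc1` gives 559 nM in an assay on isolated protein for agonist activity at Free fatty acid receptor 1 (Homo sapiens); a higher number here means that more compound is needed for the effect, a lower number that less compound is needed. Compound 2 `CC#CC(CC(=O)O)c1ccc(OCc2ccc3nc(-c4ccc(F)cc4F)cn3c2)cc1` gives 825 nM in this assay, a number within the usual scatter of that for compound 1, so the two cannot be told apart. Compound 3 `CC#CC(CC(=O)O)c1ccc(OCc2ccn3cc(-c4ccc(F)cc4F)nc3c2)cc1` has not yet been measured; it differs from compound 1 by 2,4-difluorophenyl in place of 4-cyclohexylphenyl on an aromatic carbon. Compound 2 carries the same 2,4-difluorophenyl group on a closely related core and gives 825 nM. For compound 3 a small shift toward a higher number is therefore expected, a 1.6-fold higher number from compound 1 to compound 3 (0.21 log units; within the scatter). Compound 3 is estimated at 900 nM, with a range from 400 nM to 2500 nM.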

Compound 3, half-maximal effective concentration: 792 nM
For compound 3 the middle estimate is 1.1-fold (0.06 log units) above the measured one; low and high end bracket the measured number.
By their numbers in this assay, from the lowest: compounds 1, 3 and 2 (each within the scatter of the next).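

Putting 2,4-difluorophenyl in place of 4-cyclohexylphenyl gives a 1.4-fold higher number from compound 1 to compound 3 (0.15 log units; within the scatter) in this assay for this change at the aromatic carbon. The non-aromatic ring of carbon only can thus leave this position, and the group can shrink from 12 heavy atoms to 8, while compound 1 and compound 3 remain impossible to tell apart. Nothing measured here offers an explanation for this result.

From the compounds shown here alone, it remains open whether an amine or a carboxylic acid on the phenyl ring would move the number beyond the scatter. The same question applies to a single fluorine in place of the two.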